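Methoxy added to the aryl ring of compound 2

The source may hold more compounds than are shown below. What is called first, only, known or untested is meant among the compounds shown, and "the series" means these compounds.

In a functional assay on LOX IMVI cells (Homo sapiens) for antiproliferative activity, with a stated time of 48 h (a lower number here means a stronger inhibitor of growth, a higher number a weaker inhibitor of growth), compound 1 `Cc1cc(O)c(C2=NN(c3ccc(S(N)(=O)=O)cc3)C(c3ccccc3O)C2)cc1Cl` gives 3190 nM and compound 2 `COc1ccc(C2CC(c3cc(Cl)c(C)cc3O)=NN2c2ccc(S(N)(=O)=O)cc2)cc1OC` gives 11000 nM; the step is a 3.4-fold higher number from compound 1 to compound 2 (0.54 log units; beyond the scatter). Compound 2 therefore holds the higher of the two numbers seen so far. Compound 3 `COc1ccc(C2CC(c3cc(Cl)c(C)cc3O)=NN2c2ccc(S(N)(=O)=O)cc2)c(OC)c1OC` differs from compound 2 by methoxy in place of hydrogen on an aromatic carbon. Among the compounds with values here, only the step from compound 1 to compound 2 touches this ring, and it is modest; no measured step adds a methoxy to it. In this assay a small shift, or none beyond the scatter, is therefore expected, if anything toward a higher number. For compound 3 the estimate is 13000 nM (range 5000 nM to 35000 nM), an expected step of a 1.2-fold higher number from compound 2 to compound 3 (0.07 log units; within the scatter).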

Compound 3, concentration for total growth inhibition: 4280 nM
Compound 3: middle estimate off by 3.0-fold (0.48 log units), on the high side; the whole stated range lies above it.
By their numbers in this assay, from the lowest: compounds 1 and 3 (each within the scatter of the next); then compound 2.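

In this assay methoxy in place of hydrogen, ortho to a large group, gives a 2.6-fold lower number from compound 2 to compound 3 (0.41 log units; beyond the scatter) and so marks this position as one where added bulk lowers the number rather than raises it. The 2,3,4-trimethoxyphenyl group in place of 2-hydroxyphenyl gives a 1.3-fold higher number from compound 1 to compound 3 (0.13 log units; within the scatter) and so leaves compound 3 and compound 1 level within the scatter. Nothing available bears on the reason for this step.

From the compounds shown here alone, whether the lower number is specific to methoxy remains open. An ethoxy group, a hydroxyl or an amine at this position would test that.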